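Replacing the oxetanyl group on the aromatic nitrogen

A few compounds are considered here, and "the series" means these few. Any claim that something is new, unique, unknown or untested is made for them only; others in the source may bear on it.

Measured compounds:
- compound 1 `Cc1nn(C2COC2)cc1Nc1nc(N)c2c(C#N)c(N3CCC[C@H]3C)n(C)c2n1`; in an assay on HEK293 cells for inhibition of Leucine-rich repeat serine/threonine-protein kinase 2 variant G2019S (Homo sapiens), with a stated time of 48 h (on this read-out lower numbers stand for stronger inhibition and higher numbers for weaker inhibition), compound 1 gives 140 nM
- compound 2 `C[C@@H]1CCCN1c1c(C#N)c2c(N)nc(Nc3cn(C)nc3Cl)nc2n1C`; in this assay compound 2 gives 54 nM

Compound 1 stands at the higher of the two numbers. Within the data shown here, its only comparator is compound 2, which carries 3-chloro-1-methyl-1H-pyrazol-4-yl in place of 3-methyl-1-(oxetan-3-yl)-1H-pyrazol-4-yl on a nitrogen on an aromatic ring; that step was a 2.6-fold lower number from compound 1 to compound 2 (0.41 log units; beyond the scatter).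

Compound 3 `Cc1nn(CC2(O)COC2)cc1Nc1nc(N)c2c(C#N)c(N3CCC[C@H]3C)n(C)c2n1` carries (3-hydroxyoxetan-3-yl)methyl in place of oxetan-3-yl on an aromatic nitrogen. Among the measured compounds shown here, no measured step isolates a change at this aromatic nitrogen alone; the step from compound 1 to compound 2 exchanges the whole group together with the ring methyl and is the only measured change touching this part of the molecule, and it was modest. A step in this assay of at most that size is therefore expected, with no firm direction. For compound 3 the expected value is 130 nM, with a range from 50 nM to 350 nM, meaning an expected step of a 1.1-fold lower number from compound 1 to compound 3 (0.03 log units; within the scatter).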

Compound 3, half-maximal inhibitory concentration: 250 nM
Compound 3: middle estimate off by 1.9-fold (0.28 log units), on the low side; measured number inside the range.
By their numbers in this assay, from the lowest: compound 2; then compounds 1 and 3 (each within the scatter of the next).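

In this assay, the step confined to the aromatic nitrogen is a 1.8-fold higher number from compound 1 to compound 3 (0.25 log units; within the scatter), so (3-hydroxyoxetan-3-yl)methyl, with 6 heavy atoms and 1 hydrogen-bond donor, cannot be told apart from oxetan-3-yl, with 4 heavy atoms and 0 hydrogen-bond donors. At this position, then, this one pair shows that the larger group with the added hydroxyl is accommodated with no step beyond the scatter, which the earlier step could not show because it also changed the ring methyl. No measurement shown here bears on the origin of this result.

As far as these compounds go, whether an amine, a carboxylic acid or a longer chain ending in hydroxyl on the same aromatic nitrogen would also stay within the scatter of compound 1 remains open. Also open, from the compounds shown here alone, is how much of a 2.6-fold lower number from compound 1 to compound 2 (0.41 log units; beyond the scatter) belongs to chlorine in place of the ring methyl and how much to the group on the aromatic nitrogen.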